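Swapping a single nitrogen for a five-membered aromatic ring

This account rests on a few compounds, and the source may have more. Where it says the series, first, only, none or still open, it means among the compounds named here.

Compound 1, whose structure is `CC1=CC[C@H](C(C)(C)NC(=S)NN)CC1`, is the starting point of this short series, but in a functional assay on UACC-62 cells (Homo sapiens) for inhibition, read by sulforhodamine B assay, with a stated time of 48 h (a lower number here means a stronger inhibitor of growth, a higher number a weaker inhibitor of growth), compound 1 gives "not determined" (no result reported), so no single number exists for it and where it stands on the scale of this assay cannot be said. Among the measured compounds shown here, the one measured relative is compound 2, with the structure `CC1=CC[C@H](C(C)(C)NC(=S)N/N=C/c2ccccc2)CC1`; in this assay compound 2 gives 31600 nM, a weak inhibitor of growth on this scale.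

The compound that has not yet been measured is compound 3, with the structure `CC1=CC[C@H](C(C)(C)NC(=S)N/N=C/c2ccc[nH]2)CC1`. It arises from compound 1 through the change (a group of 7 heavy atoms (5 carbon, 2 nitrogen; one five-membered aromatic ring with 1 hetero atom) in place of one nitrogen atom, on an amide-type nitrogen). For the measured compounds named here, with no value for compound 1, the size of this step cannot be read from the data, and no step between two measured compounds is available for comparison.

Because compound 2 gives 31600 nM in this assay, and compound 3 differs from it only in the ring that enters, a value of similar weakness seems the most likely outcome for compound 3, with no step beyond the usual scatter expected in either direction. Compound 3 is therefore estimated at about 28000 nM in this assay, within a range from 9000 nM to 90000 nM.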

Compound 3, concentration for 50% growth inhibition: 14800 nM
For compound 3 the middle estimate is 1.9-fold (0.28 log units) above the measured one, within the range that was stated.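

In this assay, putting 1H-pyrrol-2-yl in place of phenyl on the carbon with a double bond to nitrogen gives a 2.1-fold lower number from compound 2 to compound 3 (0.33 log units; beyond the scatter), a modest step but one beyond the usual scatter, so the identity of the ring at this place does affect growth inhibition. Even so, compound 3 at 14800 nM remains a weak inhibitor of growth on this scale, and compound 1 has no number, so the step from compound 1 to compound 3 cannot be read and the effect of adding the whole ring-bearing group to the amide-type nitrogen stays unknown. Nothing in the data bears on why the five-membered ring gives the lower number.

Among the compounds shown here, with only two rings to compare, a single step cannot show whether other rings, such as furan-2-yl, thiophen-2-yl or pyridin-2-yl, would go further in the same direction. From the compounds shown here alone, it also remains open how a small group on the ring, such as a methyl or a hydroxyl, or an open chain in place of the ring, would behave at this place.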